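Replacing 4-methylpiperazin-1-yl with (pyridin-2-yl)sulfanyl on the shared core

This account rests on a few compounds, and the source may have more. Where it says the series, first, only, none or still open, it means among the compounds named here.

For the measured compounds named here, in a functional assay on PC-3 cells (Homo sapiens) for inhibition, read by MTT assay, with a stated time of 72 h (a higher number here means a weaker inhibitor, a lower number a stronger inhibitor), compound 1 (`CN1CCN(c2cc(C(F)(F)F)nc(SCc3ccc(C(F)(F)F)cc3)n2)CC1`) gives 34700 nM, the only actual number available so far. Compound 2 (`FC(F)(F)c1ccc(CSc2nc(N3CCN(c4ccccn4)CC3)cc(C(F)(F)F)n2)cc1`) gives > 50000 nM, which is a limit of the assay and not a number. Going by the values given here, the one measured step is an at least 1.4-fold higher number from compound 1 to compound 2 (0.15 log units; that floor lies within the scatter), with pyridin-2-yl in place of methyl on an amine nitrogen in a ring.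

Compound 3 (`FC(F)(F)c1ccc(CSc2nc(Sc3ccccn3)cc(C(F)(F)F)n2)cc1`) differs from compound 1 by another change, ((pyridin-2-yl)sulfanyl in place of 4-methylpiperazin-1-yl on an aromatic carbon), with (pyridin-2-yl)sulfanyl in place of 4-methylpiperazin-1-yl on an aromatic carbon. The measured step shares only the pyridin-2-yl group with this change, so it bears on it loosely and gives no firm direction. No shift beyond the scatter is therefore expected in this assay. The expected step is a 1.2-fold lower number from compound 1 to compound 3 (0.06 log units; within the scatter). Compound 3 is estimated at 30000 nM, with an expected range from 10000 nM to 50000 nM.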

Compound 3, half-maximal inhibitory concentration: 25200 nM
The estimate for compound 3 lay 1.2-fold (0.08 log units) above the measured number; the range from low to high includes it.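

Exchanging 4-methylpiperazin-1-yl for (pyridin-2-yl)sulfanyl on this aromatic carbon gives, in this assay, a 1.4-fold lower number from compound 1 to compound 3 (0.14 log units; within the scatter). The position therefore holds either a six-membered non-aromatic ring with 2 hetero atoms or a six-membered aromatic ring with 1 hetero atom, and the two values cannot be told apart in this assay, so the 4-methylpiperazin-1-yl group is not needed to keep the number of compound 1. Compound 2 remains a limit of the assay and not a number: the limit of > 50000 nM in this assay, at which 1 of the 3 values shown sits.

This change swaps the ring and the linking atom at once, so the compounds shown do not separate what each contributes. From the compounds shown here alone, a phenylsulfanyl group, a pyridin-2-yloxy group or a morpholine ring on this carbon would bear on that, and whether any group here can move the number beyond the scatter remains open.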